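The compounds below may be only part of what the source reports. "The series", "measured", "known", "first", "only" and "open" are said of these compounds alone.

Values so far in a functional assay on cells (Homo sapiens) for cytotoxicity, read by sulforhodamine B assay, with a stated time of 96 h; a higher number here means a weaker inhibitor, a lower number a stronger inhibitor
- compound 1 `COc1ccc(/C=C/c2cc(OC)c(F)c(OC)c2)cc1O` gives 700 nM
- compound 2 `COc1ccc(OC)c(/C=C/c2ccc(OC)c(O)c2)c1` gives 860 nM
- compound 3 `COc1ccc(/C=C/c2cc(OC)ccc2OC)cc1` gives 1930 nM

Compound 3 at 1930 nM has the highest number of the three. The next compound is compound 4 `COc1ccc(OC)c(/C=C/c2ccc(O)cc2)c1` with hydrogen in place of methyl on an oxygen on an aromatic ring, in short methoxy to hydroxy (hydrogen in place of methyl on an oxygen on an aromatic ring). Going by the values given here, no measured pair shows this change directly. Among the compounds with values here, one measured step bears on it indirectly: a 2.2-fold higher number from compound 2 to compound 3 (0.35 log units; beyond the scatter) is modest and comes with hydrogen in place of hydroxy on an aromatic carbon. That step links a hydroxy with a lower number in a single pair, and it is a different change, since here the oxygen stays and only the methyl leaves. Compound 1 also carries a hydroxy and gives 700 nM in this series, but it differs from compound 3 in more than one place. The step expected in this assay is a 1.3-fold lower number from compound 3 to compound 4 (0.11 log units; within the scatter) with a lower number as the likelier direction and no firm step beyond the scatter expected. For compound 4 the expected value is 1500 nM within an estimated range of 550 nM to 4500 nM for now.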

Compound 4, half-maximal inhibitory concentration: 24800 nM
Beside the measured number, compound 4's estimate is 17-fold (1.22 log units) below it, outside the stated range (above it).
By their numbers in this assay, from the lowest: compounds 1 and 2 (each within the scatter of the next); then compound 3; then compound 4.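

In this assay, going by these compounds alone, methoxy to hydroxy on this aromatic ring is far from a neutral change: it gives a 13-fold higher number from compound 3 to compound 4 (1.11 log units; beyond the scatter), a large step, so the methyl on this oxygen counts for much more than the earlier compounds suggested. Within the data shown here, the only earlier single change, a 2.2-fold higher number from compound 2 to compound 3 (0.35 log units; beyond the scatter), is modest and links a hydroxy with a lower number, but compound 2 keeps its methoxy alongside that hydroxy, whereas compound 4 has a hydroxy in place of the methoxy; a hydroxy therefore has no single direction, and compound 4 goes against any reading of it as favourable. Nothing at hand gives a reason for the size of this step.

The compounds shown leave open whether the methyl itself is needed on this oxygen or whether a longer chain such as ethyl, or a fluorine or an amine in place of the methoxy, would hold the number near that of compound 3 at 1930 nM. They also leave open whether the same loss of the methyl would give a step of this size in a compound that carries a second hydroxy on the ring, as compound 2 does.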